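A few compounds are considered here, and "the series" means these few. Any claim that something is new, unique, unknown or untested is made for them only; others in the source may bear on it.

Compound 1 `O=C(NCCCCn1cccn1)c1cccc(C2SCC(=O)N2c2cccnc2)c1`: > 1000 nM (a limit)
Compound 2 `O=C(NCCCCn1cccn1)c1cccc(C2SCC(=O)N2c2cccc(C3CC3)c2)c1`: 299 nM
Compound 3 `O=C(NCCCCn1cccn1)c1cccc(C2SCC(=O)N2c2cc(F)ccn2)c1`: not yet measured

Both measured compounds were tested in a functional assay on HOS-TE85 cells (Homo sapiens) for inhibition, read by CCK-8 assay, with a stated time of 72 h; a lower number here means a stronger inhibitor, a higher number a weaker inhibitor. Compound 1 reached only a limit of the assay, > 1000 nM, and not a number. For the measured compounds named here, compound 2 gives 299 nM, the only true number so far, and is the stronger inhibitor of the pair. Going by the values given here, the one measured step is an at least 3.3-fold lower number from compound 1 to compound 2 (0.52 log units; beyond the scatter), with 3-cyclopropylphenyl in place of pyridin-3-yl on an amide-type nitrogen in a ring. As far as these compounds go, its full size is unknown, since it starts from the limit of > 1000 nM in this assay, at which 1 of the 2 values shown sits.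

Compound 3 changes the same place: 4-fluoropyridin-2-yl in place of 3-cyclopropylphenyl on an amide-type nitrogen in a ring. Here 4-fluoropyridin-2-yl stands in place of 3-cyclopropylphenyl, which comes close to reversing that step. Among the compounds with values here, no measured compound carries 4-fluoropyridin-2-yl, so the guide is imperfect. Even so, a loss of inhibition is expected in this assay because an at least 3.3-fold lower number from compound 1 to compound 2 (0.52 log units; beyond the scatter) accompanied the arrival of the group that now leaves. The expected change is a 2.7-fold higher number from compound 2 to compound 3 (0.43 log units; beyond the scatter), towards weaker inhibition, and a limit may be reported again. For compound 3 the estimated value is 800 nM, with an expected range of 250 nM to 2500 nM.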

Compound 3, half-maximal inhibitory concentration: 33.2 nM
Beside the measured number, compound 3's estimate is 24-fold (1.38 log units) above it, and the stated range ends above it.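

In this assay, the group on the amide-type nitrogen in a ring need not be a carbon-only aromatic ring bearing cyclopropyl to give strong inhibition, and the best result shown so far comes from a smaller group: the change to 4-fluoropyridin-2-yl gives a 9.0-fold lower number from compound 2 to compound 3 (0.95 log units; beyond the scatter). The nitrogen-containing ring is therefore not a liability in itself, since pyridin-3-yl and 4-fluoropyridin-2-yl both carry one and yet the comparison between them is an at least 30-fold lower number from compound 1 to compound 3 (1.47 log units; beyond the scatter). The full size of that step is unknown, as compound 1 gave only a limit of the assay and not a number: the limit of > 1000 nM in this assay, at which 1 of the 3 values shown sits.

As far as these compounds go, what stays open is whether the gain over compound 1 belongs to the fluorine or to the change from pyridin-3-yl to a pyridin-2-yl group, which plain pyridin-2-yl, or a chlorine or methoxy group in place of the fluorine, would separate. From the compounds shown here alone, it is also open whether the same order of groups holds with a shorter chain on the amide in place of the butyl chain bearing the pyrazole.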